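From compound 3 to its chloro analogue, compound 4

The source may hold more compounds than are shown below. What is called first, only, known or untested is meant among the compounds shown, and "the series" means these compounds.

Values in a functional assay on K562 cells (Homo sapiens) for cytotoxicity, with a stated time of 72 h; on this read-out higher numbers stand for weaker inhibition and lower numbers for stronger inhibition:
Compound 1 `Cc1cc(-c2c(-c3cccc(C)n3)nn3c2C(C)C(C)(C)C3)ccn1`: > 100000 nM (a limit)
Compound 2 `Cc1cccc(-c2nn3c(c2-c2ccnc(Nc4ccc(S(N)(=O)=O)cc4)c2)C(C)C(C)(C)C3)n1`: 31000 nM
Compound 3 `Cc1cccc(-c2nn3c(c2-c2ccncc2)C(C)C(C)(C)C3)n1`: > 100000 nM (a limit)

Compound 3 sits at the limit of > 100000 nM in this assay, at which 2 of the 3 values shown sit. Compound 4 `Cc1cccc(-c2nn3c(c2-c2ccnc(Cl)c2)C(C)C(C)(C)C3)n1` has chloro in place of hydrogen on an aromatic carbon, next to the ring nitrogen: chloro in place of hydrogen on an aromatic carbon. The steps at this same carbon bear on the change. Replacing methyl with (4-sulfamoylphenyl)amino gives an at least 3.2-fold lower number from compound 1 to compound 2 (0.50 log units; beyond the scatter), and replacing that group with hydrogen gives an at least 3.2-fold higher number from compound 2 to compound 3 (0.50 log units; beyond the scatter). Between methyl and hydrogen there is a step that the two limits leave unreadable from compound 1 to compound 3. With only these steps to go on, chloro is expected to bring at most a modest fall in the number. Compound 4 is expected at 80000 nM, with an estimated range of 30000 nM to 150000 nM. The expected step is an at least 1.2-fold lower number from compound 3 to compound 4 (0.09 log units; that floor lies within the scatter).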

Compound 4, half-maximal inhibitory concentration: > 100000 nM
Compound 4 gave a limit, no number; the forecaster's own chance of this, stated with the estimate: 60%; middle value at least 1.2-fold (0.09 log units) from the limit.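

In this assay compound 4 gives > 100000 nM, which is a limit and not a number. Chloro at this carbon therefore joins hydrogen and methyl at the limit, and the steps among these three cannot be read; only (4-sulfamoylphenyl)amino gives a measured number here, and chloro in its place brings an at least 3.2-fold higher number from compound 2 to compound 4 (0.50 log units; beyond the scatter). The limit now holds most of the values: the limit of > 100000 nM in this assay, at which 3 of the 4 values shown sit.

As far as these compounds go, whether a simple amine, such as methylamino, would also give a measured number at this carbon remains open. So does whether a phenylamino group without the sulfamoyl part would do so.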